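The source may hold more compounds than are shown below. What is called first, only, known or untested is meant among the compounds shown, and "the series" means these compounds.

Measured so far in an assay on cell membranes for binding affinity to Fatty-acid amide hydrolase 1 (Rattus norvegicus); on this read-out lower numbers stand for stronger inhibition and higher numbers for weaker inhibition:
compound 1 `Cc1ccc(-c2cccc(OC(=O)NC3CCCCC3)c2)cc1` gives 155 nM
compound 2 `NC(=O)c1ccc(-c2cccc(OC(=O)NC3CCCCC3)c2)cc1` gives 5910 nM
compound 3 `O=C(NC1CCCCC1)Oc1cccc(-c2cccc(OC(=O)NC3CCCCC3)c2)c1` gives 361 nM

Compound 3 holds the second highest of the three numbers in this assay; compound 1 stands nearest to it and compound 2 furthest. Compound 4 `O=C(NC1CCCCC1)Oc1cccc(-c2cccc([N+](=O)[O-])c2)c1` is not yet measured. It differs from compound 3 by nitro in place of (cyclohexylcarbamoyl)oxy on an aromatic carbon. Going by the values given here, the one measured step that bears on it, a polar group replacing a small one on the same ring, was a 38-fold higher number from compound 1 to compound 2 (1.58 log units; beyond the scatter), a large rise. The step expected here is judged smaller, since compound 1 with methyl and compound 3 with the carbamate already differ less. For compound 4 a rise of about a 4.2-fold higher number from compound 3 to compound 4 (0.62 log units; beyond the scatter) is expected. Compound 4 is therefore estimated at 1500 nM, within 400 nM to 6000 nM.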

Compound 4, half-maximal inhibitory concentration: 49.6 nM
Compound 4: the middle estimate sits 30-fold (1.48 log units) above what was measured; the whole stated range lies above it.
By their numbers in this assay, from the lowest: compound 4; then compound 1; then compound 3; then compound 2.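

In this assay, nitro in place of (cyclohexylcarbamoyl)oxy gives a 7.3-fold lower number from compound 3 to compound 4 (0.86 log units; beyond the scatter), so the cyclohexyl carbamate is not needed at this aromatic carbon for a low number. A group of 3 heavy atoms, with no ring and no hydrogen-bond donor, does better here than the group of 10 heavy atoms it replaces. From the compounds shown here alone, whether an amine, a nitrile or a carboxylic acid on this carbon would also give a low number remains open. No measured evidence here accounts for this fall.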